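A few compounds are considered here, and "the series" means these few. Any claim that something is new, unique, unknown or untested is made for them only; others in the source may bear on it.

Compound 1 `COc1ccc([C@H]2Oc3cc(OC)c(OC)cc3[C@@H]2C)cc1O` was tested in a functional assay on Ca9-22 cells (Homo sapiens) for cytotoxicity, read by MTT assay; on this read-out lower numbers stand for stronger inhibition and higher numbers for weaker inhibition. In this assay compound 1 gives > 19.4 ug/mL, which is a limit of the assay rather than a number. Compound 1 thus stands at the limit of > 19.4 ug/mL in this assay, at which 1 of the 2 values shown sits. Compound 2 `COc1ccc(-c2oc3cc(OC)c(O)cc3c2C)cc1O` is reported in this assay only as "not active" (no number reported). Compound 3 `COc1ccc([C@H]2Oc3cc(OC)c(O)cc3[C@@H]2C)cc1O` has not yet been measured; it differs from compound 1 by hydrogen in place of methyl on an oxygen on an aromatic ring. Within the data shown here, with no measured step between these compounds to draw on, the step that the limit leaves unreadable from compound 1 to compound 3 is expected to stay within the scatter. Compound 3 is estimated at 25 ug/mL, with a range from 10 ug/mL to 60 ug/mL.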

Compound 3, half-maximal inhibitory concentration: 7.7 ug/mL
Compound 3: the middle estimate sits 3.2-fold (0.51 log units) above what was measured; measured number below the stated range.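

In this assay, changing methoxy to hydroxy, on an oxygen on an aromatic ring, gives an at least 2.5-fold lower number from compound 1 to compound 3 (0.40 log units; beyond the scatter). Among these compounds, this is the first readable sign that the read-out responds to a change at this position, and a change of a single methyl is enough to produce it. The true size of the step stays unknown because one end of it is a limit of the assay: the limit of > 19.4 ug/mL in this assay, at which 1 of the 3 values shown sits.

The compounds shown leave open how a longer chain on that oxygen, such as ethoxy, would read. They also leave open what an amine or a fluorine in place of the hydroxy would do.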